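From piperidin-4-yl to 4-hydroxybutyl on the shared core

This account rests on a few compounds, and the source may have more. Where it says the series, first, only, none or still open, it means among the compounds named here.

In a functional assay on MDA-MB-231 cells (Homo sapiens) for inhibition, read by MTT assay, with a stated time of 72 h (on this read-out higher numbers stand for weaker inhibition and lower numbers for stronger inhibition), compound 1 `CC(C)=CCC[C@H](C)c1ccc(C)c(CNCCO)c1O` gives 14400 nM and compound 2 `CC(C)=CCC[C@H](C)c1ccc(C)c2c1OCN(CC1CCNCC1)C2` gives 14900 nM so that the two values lie within the scatter of each other and compound 2 stands level with compound 1. Going by the values given here, these two compounds differ in more than one place, and no measured step isolates a single change. Compound 3 `CC(C)=CCC[C@H](C)c1ccc(C)c2c1OCN(CCCCCO)C2` keeps the shared core of compound 2 and differs from it by 4-hydroxybutyl in place of piperidin-4-yl on a saturated chain carbon bound to an amine nitrogen in a ring with 4-hydroxybutyl in place of piperidin-4-yl on a saturated chain carbon bound to an amine nitrogen in a ring. Among the compounds with values here, with no measured step to guide the direction, the expected step of a 1.2-fold lower number from compound 2 to compound 3 (0.09 log units; within the scatter) is none beyond the scatter. In this assay compound 3 is estimated at 12000 nM with a range from 6000 nM to 25000 nM expected.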

Compound 3, half-maximal inhibitory concentration: 5400 nM
Compound 3: middle estimate off by 2.2-fold (0.35 log units), on the high side; measured number below the stated range.
By their numbers in this assay, from the lowest: compound 3; then compounds 1 and 2 (each within the scatter of the next).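

In this assay, going by these compounds alone, 4-hydroxybutyl in place of piperidin-4-yl on a saturated chain carbon bound to an amine nitrogen in a ring gives a 2.8-fold lower number from compound 2 to compound 3 (0.44 log units; beyond the scatter) as a modest step, the only step that can be read. This position therefore responds to the group it carries: the ring can give way to an open chain with a hydroxyl at its end, and the number falls. The leaving and entering groups have the same hydrogen-bond donor and acceptor counts, so those counts do not separate compound 2 from compound 3, and nothing available explains the step.

Still open, on these data alone, is whether the hydroxyl or the open chain itself accounts for the step. A plain pentyl chain and a pentyl chain ending in an amine would help separate the two in this place.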